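Fluorine Added to a Series That Stays Well Tolerated

A few compounds are considered here, and "the series" means these few. Any claim that something is new, unique, unknown or untested is made for them only; others in the source may bear on it.

Of the compounds shown here, three have been measured in a functional assay on MT4 cells (Homo sapiens) for cytotoxicity, read by MTT assay, with a stated time of 5 days; a higher number here means that more compound is tolerated, a lower number that less compound is tolerated. Compound 1 `N#Cc1ccc(Nc2nccc(Oc3ccc(-c4ccc(C#N)cc4)c(F)c3)n2)cc1` gives a value that is a limit of the assay rather than a number, > 307000 nM. Compound 2 `N#Cc1ccc(Nc2nccc(Oc3ccc(-c4ccc(C#N)cc4)c(F)c3F)n2)cc1` likewise gives only a limit, > 294000 nM. The change from compound 1 to compound 2 is fluoro in place of hydrogen on an aromatic carbon. The step that the two limits leave unreadable from compound 1 to compound 2 cannot be read because the limit of > 307000 nM in this assay, at which 1 of the 3 values shown sits, and the limit of > 294000 nM in this assay, at which 1 of the 3 values shown sits, are both limits. Compound 3 `Cc1cc(-c2ccc(C#N)cc2)ccc1Oc1ccnc(Nc2ccc(C#N)cc2)n1` rests on a different core; the difference between the two cores is not broken down here. In this assay compound 3 again reaches only a limit, > 310000 nM. That this value sits at a limit is recorded as the limit of > 310000 nM in this assay, at which 1 of the 3 values shown sits.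

Compound 4 `Cc1cc(-c2ccc(C#N)cc2F)ccc1Oc1ccnc(Nc2ccc(C#N)cc2)n1` is not yet measured. It differs from compound 3 by fluoro in place of hydrogen on an aromatic carbon. Going by the values given here, this is the same kind of change as the one from compound 1 to compound 2, but not the same: in compound 2 the entering fluoro sits ortho to a fluoro group and meta to a 4-cyanophenyl group, whereas in compound 4 it sits meta to a cyano group. Among the compounds with values here, with every measured value stopping at a limit, no measured step offers a size to lean on. The expectation rests on compound 3 giving > 310000 nM, a limit. Compound 4 is therefore expected to remain at the top of what this assay can read, with an estimated value of 310000 nM and a range from 100000 nM to 600000 nM. The step of a number no higher from compound 3 to compound 4 (the limit leaves the size open) is the estimated one, taken as flat.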

Compound 4, half-maximal cytotoxic concentration: > 296000 nM
Compound 4: no number, only a limit; the forecaster's own chance of this, stated with the estimate: 85%; the middle value does not contradict the limit.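

In this assay compound 4, like compound 3, gives only a limit of the assay rather than a number, so no size can be read for the step between compound 3 and compound 4. The four compounds shown leave open at what concentration any of them would stop being tolerated in this assay, and whether fluoro in place of hydrogen shifts that concentration at all.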